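Acetyl in place of trifluoromethyl on the shared core

The source may hold more compounds than are shown below. What is called first, only, known or untested is meant among the compounds shown, and "the series" means these compounds.

Compound 1 (`COc1ccc(-c2nc3cc(C(F)(F)F)ccc3[nH]2)c(OC)c1`) is the starting point of this comparison. In an ADME assay on BHK cells (Mesocricetus auratus) for cytotoxicity, read by MTT assay, with a stated time of 96 h (on this read-out lower numbers stand for higher toxicity in this test and higher numbers for lower toxicity in this test), compound 1 gives > 100000 nM, which is a limit of the assay and not a number. Its true position can therefore not be read from the data. Compound 2 (`COc1ccc(-c2nc3cc(C(F)(F)F)ccc3[nH]2)c([N+](=O)[O-])c1`) has nitro in place of methoxy on an aromatic carbon, and in this assay compound 2 gives 100000 nM. Among the compounds with values here, the only measured step is a number no higher from compound 1 to compound 2 (the limit leaves the size open). Its size cannot be read, and it concerns methoxy, not trifluoromethyl, so it bears on the present change only indirectly.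

Compound 3 (`COc1ccc(-c2nc3cc(C(C)=O)ccc3[nH]2)c(OC)c1`) differs from compound 1 by acetyl in place of trifluoromethyl on an aromatic carbon, which is acetyl in place of trifluoromethyl on an aromatic carbon. Within the data shown here, no measured step covers this exchange. Among the measured compounds shown here, with compound 2 at 100000 nM as the only measured number, a modest step towards lower numbers, or none beyond the scatter, is expected. The estimated change is an at least 1.4-fold lower number from compound 1 to compound 3 (0.15 log units; that floor lies within the scatter). For compound 3 the expected value is 70000 nM, within an estimated range from 20000 nM to 100000 nM.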

Compound 3, half-maximal cytotoxic concentration: > 100000 nM
Compound 3 ended at the assay's limit; the forecaster's own chance of this, stated with the estimate: 50%; middle value at least 1.4-fold (0.15 log units) away from the limit.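

In this assay compound 3 gives > 100000 nM, which is a limit of the assay and not a number. Compound 1 stands at the same limit, so no step between compound 1 and compound 3 can be read: the limit of > 100000 nM in this assay, at which 2 of the 3 values shown sit.

The compounds shown leave open whether acetyl in place of trifluoromethyl on the shared core changes the read-out at all, and in which direction.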